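This account rests on a few compounds, and the source may have more. Where it says the series, first, only, none or still open, it means among the compounds named here.

Three compounds that share one core have been run in a functional assay on the whole organism (Tail, strain ICR) with Mus musculus as the target, in the tail flick test, with a stated time of 150 min, at a dose of 25 umol/kg by the oral route; on this read-out lower numbers stand for a weaker effect and higher numbers for a stronger effect at the one dose given. Compound 1 `NC(=O)C[C@H](NC(=O)CN(c1nc(Cl)nc2[nH]cnc12)C1CC1)C(=O)O` gives 7.51%. Compound 2 `NCCCC[C@H](NC(=O)CN(c1nc(Cl)nc2[nH]cnc12)C1CC1)C(=O)O` gives 11.6%, and compound 3 `CSCC[C@H](NC(=O)CN(c1nc(Cl)nc2[nH]cnc12)C1CC1)C(=O)O` gives 4.14%. Compound 1 stands second highest of the three numbers: its nearest neighbour is compound 3, with a number 3.4 percentage points lower from compound 1 to compound 3 (within the scatter), and its furthest is compound 2, with a number 4.1 percentage points higher from compound 1 to compound 2 (within the scatter). Between the other two the step is a number 7.5 percentage points lower from compound 2 to compound 3 (within the scatter). All three steps lie within the scatter, so the numbers do not separate the compounds.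

Compound 4 `NC(=O)C[C@H](NC(=O)CN(c1nc(Cl)nc2[nH]cnc12)C1CC1)C(=O)OCc1ccccc1` has not yet been measured. It differs from compound 1 by benzyl in place of hydrogen on an oxygen next to a carbonyl group. Among the compounds with values here, none of the measured steps concerns the oxygen next to a carbonyl group: each of them exchanges the group on the saturated chain carbon, so no measured step bears directly on this change. With nothing pointing either way, no step beyond the scatter is expected, and the estimated step is a number 0.5 percentage points higher from compound 1 to compound 4 (within the scatter). Compound 4 is therefore expected to give about 8%, with a range of 0% to 25%.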

Compound 4, a percentage reported as activity, at one dose (the size of the read-out at that dose, not a potency): 13.5%
For compound 4 the middle estimate is 5.5 percentage points below the measured one; the measured number falls inside the stated range.
By their numbers in this assay, from the lowest: compounds 3, 1, 2 and 4 (each within the scatter of the next).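

Within the data shown here, compound 4 brings in the oxygen next to a carbonyl group, a place the earlier steps did not touch, and in this assay the change from carboxy to benzyloxycarbonyl gives a number 6 percentage points higher from compound 1 to compound 4 (within the scatter). This position therefore takes benzyl, with its six-membered aromatic ring, in place of hydrogen without a step beyond the scatter, so the free carboxy group is not shown to be required for the read-out at this dose. Nothing measured here speaks to what lies behind this result.

The compounds shown leave open whether methyl or ethyl on this oxygen, or a primary amide in place of the carboxy group, would read the same in this assay. They also leave open whether benzyl on the same oxygen of compound 2 or compound 3 would give a step beyond the scatter.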